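Swapping 3,4-dimethoxyphenyl for chloro in compound 2

The compounds below may be only part of what the source reports. "The series", "measured", "known", "first", "only" and "open" are said of these compounds alone.

Measured in a functional assay on A549 cells (Homo sapiens) for inhibition, read by MTT assay, with a stated time of 72 h; a lower number here means a stronger inhibitor, a higher number a weaker inhibitor:
- Compound 1 `COc1ccc(-c2cc(C(=O)N3CCC4(CC3)CC(=O)c3nn(C(C)(C)C)cc3O4)c3ccccc3n2)cc1`: 3740 nM
- Compound 2 `COc1ccc(-c2cc(C(=O)N3CCC4(CC3)CC(=O)c3nn(C(C)(C)C)cc3O4)c3ccccc3n2)cc1OC`: 2030 nM
- Compound 3 `CC(C)(C)n1cc2c(n1)C(=O)CC1(CCN(C(=O)c3cc(N4CCNCC4)nc4ccccc34)CC1)O2`: > 10000 nM

The entry for compound 3 is a limit of the assay, not a number (the limit of > 10000 nM in this assay, at which 1 of the 3 values shown sits). Compound 2 cannot be separated from its nearest neighbour: a 1.8-fold lower number from compound 1 to compound 2 (0.27 log units; within the scatter). Compound 4 `CC(C)(C)n1cc2c(n1)C(=O)CC1(CCN(C(=O)c3cc(Cl)nc4ccccc34)CC1)O2` has chloro in place of 3,4-dimethoxyphenyl on an aromatic carbon, next to the ring nitrogen (chloro in place of 3,4-dimethoxyphenyl on an aromatic carbon).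

For the measured compounds named here, the closest precedent is a replacement of the aryl group on that same carbon, which gave an at least 4.9-fold higher number from compound 2 to compound 3 (0.69 log units; beyond the scatter). A similar replacement gave an at least 2.6-fold higher number from compound 1 to compound 3 (0.42 log units; beyond the scatter). A modest rise in this assay is therefore expected, and the estimated change is a 3.9-fold higher number from compound 2 to compound 4 (0.60 log units; beyond the scatter). For compound 4 the estimate is 8000 nM, with an expected range from 3000 nM to 20000 nM.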

Compound 4, half-maximal inhibitory concentration: 7170 nM
Compound 4: the middle estimate sits 1.1-fold (0.05 log units) above what was measured; low and high end bracket the measured number.
By their numbers in this assay, from the lowest: compounds 2, 1 and 4 (each within the scatter of the next, the first and the last beyond it). At a limit, above all of these: compound 3.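

In this assay, a lone chloro on this carbon, next to the ring nitrogen, still gives a measured number, so an aromatic ring here is not needed for one. The step is a 3.5-fold higher number from compound 2 to compound 4 (0.55 log units; beyond the scatter), but against the other aryl compound it is a 1.9-fold higher number from compound 1 to compound 4 (0.28 log units; within the scatter), so the first comparison lies beyond the scatter and the second within it. Compound 3 carries a limit: the limit of > 10000 nM in this assay, at which 1 of the 4 values shown sits. The step that includes this limit is only a floor, an at least 1.3-fold lower number from compound 3 to compound 4 (0.14 log units; that floor lies within the scatter), and it does not separate the two compounds.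

From the compounds shown here alone, whether a methyl or a simple amine on this carbon would differ from chloro remains open. So does whether an aryl ring bearing a carboxylic acid would give a lower number than compound 2.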